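Sulfur-linked side chains: from compound 3 to compound 4

A few compounds are considered here, and "the series" means these few. Any claim that something is new, unique, unknown or untested is made for them only; others in the source may bear on it.

Compound 1 `Cc1cc(N2CC[C@@H](C)[C@@H](N(C)c3ncnc4[nH]ccc34)C2)n2nc(SCc3ccc(Cl)cc3)nc2n1`: 16000 nM
Compound 2 `Cc1cc(N2CC[C@@H](C)[C@@H](N(C)c3ncnc4[nH]ccc34)C2)n2nc(SCc3csc4ccc(Cl)cc34)nc2n1`: > 100000 nM (a limit)
Compound 3 `Cc1cc(N2CC[C@@H](C)[C@@H](N(C)c3ncnc4[nH]ccc34)C2)n2nc(SCc3ccc(F)cc3)nc2n1`: 11900 nM

All three were read in a functional assay on MGC-803 cells (Homo sapiens) for inhibition, read by MTT assay, with a stated time of 72 h; on this read-out higher numbers stand for weaker inhibition and lower numbers for stronger inhibition. Among the measured compounds shown here, compound 3 holds one of only two numeric values and lies within the scatter of compound 1: a 1.3-fold lower number from compound 1 to compound 3 (0.13 log units; within the scatter). Compound 2 gives only a limit of this assay.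

Compound 4 `Cc1cc(N2CC[C@@H](C)[C@@H](N(C)c3ncnc4[nH]ccc34)C2)n2nc(SCCc3ccccc3)nc2n1` follows from compound 3 by benzyl in place of 4-fluorophenyl on a saturated chain carbon bound to a sulfur, with benzyl in place of 4-fluorophenyl on a saturated chain carbon bound to a sulfur. The large steps involve only the 5-chloro-1-benzothiophen-3-yl of compound 2: an at least 6.2-fold higher number from compound 1 to compound 2 (0.79 log units; beyond the scatter) and an at least 8.4-fold lower number from compound 2 to compound 3 (0.92 log units; beyond the scatter). Compound 4 keeps one six-membered aromatic ring of carbon only, so the closer guide is compound 1 with a 1.3-fold lower number from compound 1 to compound 3 (0.13 log units; within the scatter). No step beyond the scatter is expected: a 1.3-fold higher number from compound 3 to compound 4 (0.10 log units; within the scatter). The estimate for compound 4 is 15000 nM, with an expected range of 5000 nM to 45000 nM.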

Compound 4, half-maximal inhibitory concentration: 6190 nM
Compound 4: middle estimate off by 2.4-fold (0.38 log units), on the high side, within the range that was stated.
By their numbers in this assay, from the lowest: compounds 4, 3 and 1 (each within the scatter of the next, the first and the last beyond it). At a limit, above all of these: compound 2.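

Moving from (4-fluorobenzyl)sulfanyl to phenethylsulfanyl leaves the number in this assay within the scatter: a 1.9-fold lower number from compound 3 to compound 4 (0.28 log units; within the scatter). Set against the chlorinated side chain, phenethylsulfanyl gives the first step beyond the scatter among the numeric values, a 2.6-fold lower number from compound 1 to compound 4 (0.41 log units; beyond the scatter), though this change removes the chloro group and alters the chain together. The step of an at least 16-fold lower number from compound 2 to compound 4 (1.20 log units; beyond the scatter) is a bound rather than a measured size, resting on the limit of compound 2: the limit of > 100000 nM in this assay, at which 1 of the 4 values shown sits.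

Which of those two changes carries the step from compound 1 remains open. Also open, as far as these compounds go, is how a 3-phenylpropyl chain or a terminal amine on the sulfur would read.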